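The source may hold more compounds than are shown below. What is called first, only, known or untested is meant among the compounds shown, and "the series" means these compounds.

Working notes on the series. Compound 1 `C=CCn1c(=O)/c(=C\c2ccc(Cl)c(Cl)c2)[nH]c(=O)/c1=C\c1ccccc1OC` has no single number in a functional assay on BGC-823 cells (Homo sapiens) for cytotoxicity, read by CCK-8 assay, with a stated time of 72 h; a higher number here means a weaker inhibitor, a lower number a stronger inhibitor: in this assay compound 1 is recorded as "not active" (no number reported). Compound 3 `C=CCn1c(=O)/c(=C\c2ccc(Cl)c(Cl)c2)[nH]c(=O)/c1=C\c1ccccc1`, which shares the allyl group on the core nitrogen, is likewise recorded in this assay as "not active" (no number reported). Within the data shown here, the only numbered member is compound 2 `COc1ccccc1/C=c1\c(=O)[nH]/c(=C/c2cccc(Cl)c2Cl)c(=O)n1C`, which in this assay gives 300 nM; compound 2 carries a methyl on the core nitrogen and a 2,3-dichlorophenyl, so no single change connects it to compound 1 and nothing can be said about the size of any step from it.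

Compound 4 `C=CCn1c(=O)/c(=C\c2cc(F)ccc2C)[nH]c(=O)/c1=C\c1ccccc1OC` differs from compound 1 by 5-fluoro-2-methylphenyl in place of 3,4-dichlorophenyl on a double-bonded chain carbon bound to an aromatic carbon. Among the measured compounds shown here, no step from compound 1 can be computed, since compound 1 has no number. Both allyl-bearing members, compound 1 and compound 3, lack a number, and the change in compound 4 leaves the allyl group and the 2-methoxyphenyl in place. Compound 4 is therefore expected to remain weak in this assay, with a fair chance of no number being reported at all. The estimate for compound 4 is 15000 nM, in the range 3000 nM to 60000 nM.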

Compound 4, half-maximal inhibitory concentration: 1600 nM
For compound 4 the middle estimate is 9.4-fold (0.97 log units) above the measured one, outside the stated range (below it).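

No step can be read between compound 1 and compound 4: in this assay compound 1 has no single number. The compounds shown leave open how the 5-fluoro-2-methylphenyl alone changes activity on the shared core. No measured evidence bears on this result.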